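The compounds below may be only part of what the source reports. "The series", "measured", "known", "first", "only" and "open" are said of these compounds alone.

Within the data shown here, in a functional assay on ECV-304 cells (Homo sapiens) for cytotoxicity, read by MTT assay, with stated times of 24 h and 12 h (on this read-out higher numbers stand for an effect only at larger amounts of compound and lower numbers for an effect already at smaller amounts), compound 1 `CCOC(=O)/C=C/c1ccccc1OCc1nc(C)c(C)nc1C` gives 1540000 nM, which puts it at the low end of the three numbers known so far. Compound 2 `CCOC(=O)/C=C/c1cccc(OC)c1OCc1nc(C)c(C)nc1C` gives 3040000 nM, within the scatter of compound 1, while compound 3 `CCOC(=O)/C=C/c1cc(Cl)ccc1OCc1nc(C)c(C)nc1C` gives 16900000 nM, clearly apart from it. Compound 4 `Cc1nc(C)c(COc2ccccc2/C=C/C(=O)O)nc1C` keeps the core of compound 1 and differs in one place: hydrogen in place of ethyl on an oxygen next to a carbonyl group. This puts hydrogen in place of ethyl on an oxygen next to a carbonyl group, so ethoxycarbonyl becomes carboxy. Among the measured compounds shown here, no measured pair shows this change, so the known steps offer only a rough guide to its size. Methoxy in place of hydrogen on an aromatic carbon gave a 2.0-fold higher number from compound 1 to compound 2 (0.30 log units; within the scatter), and chloro in place of hydrogen on an aromatic carbon gave an 11-fold higher number from compound 1 to compound 3 (1.04 log units; beyond the scatter). Those steps show that a single change can leave the number alone or move it a long way, so a moderate rise is expected, with the direction uncertain. The estimated step is a 1.9-fold higher number from compound 1 to compound 4 (0.29 log units; within the scatter). For compound 4 the expected value is 3000000 nM, with an estimated range from 500000 nM to 18000000 nM.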

Compound 4, half-maximal effective concentration: 499000 nM
Estimate against measurement, compound 4: 6.0-fold (0.78 log units) above, outside the stated range (below it).
By their numbers in this assay, from the lowest: compound 4; then compounds 1 and 2 (each within the scatter of the next); then compound 3.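

In this assay, putting hydrogen in place of ethyl on an oxygen next to a carbonyl group, which turns ethoxycarbonyl into carboxy, gives a 3.1-fold lower number from compound 1 to compound 4 (0.49 log units; beyond the scatter). This is the first change shown that lowers the number beyond the scatter, meaning the effect appears at smaller amounts of compound, and it lies at the ethoxycarbonyl group rather than on an aromatic carbon, where neither of the two earlier changes lowered the number. Nothing available here explains this drop.

On these data alone, it remains open whether methyl or a longer chain on that oxygen, or an amine in place of ethoxy, would give a similarly low number. As far as these compounds go, it is also open whether the same change to carboxy would lower the number when methoxy or chloro sits on the aromatic carbon.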